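Tert-butyl analogue of the phenyl lactone series

A few compounds are considered here, and "the series" means these few. Any claim that something is new, unique, unknown or untested is made for them only; others in the source may bear on it.

Compound 1 `CCOC(=O)C12C(=O)OCC=C1COC2c1ccccc1` is the unsubstituted phenyl parent. In a functional assay on QGY cells (Homo sapiens) for cytotoxicity, read by MTT assay (on this read-out higher numbers stand for weaker inhibition and lower numbers for stronger inhibition), compound 1 gives only a limit, > 1000000 nM. Compound 2 `CCOC(=O)C12C(=O)OCC=C1COC2c1ccc(F)cc1` carries fluoro in place of hydrogen on an aromatic carbon. In this assay compound 2 likewise gives only a limit, > 1000000 nM. Compound 3 `CCOC(=O)C12C(=O)OCC=C1COC2c1ccc(Cl)c(Cl)c1` is the dichloro analogue. In this assay compound 3 also gives only a limit, > 1000000 nM. The step that the two limits leave unreadable from compound 1 to compound 2 is not readable: both ends are limits, as is every value in the set (the limit of > 1000000 nM in this assay, at which 3 of the 3 values shown sit). On the numbers shown compound 1 stands at the limit, and the two further values are limits as well.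

Compound 4 `CCOC(=O)C12C(=O)OCC=C1COC2c1ccc(C(C)(C)C)cc1` differs from compound 1 by tert-butyl in place of hydrogen on an aromatic carbon, the change sitting on an aromatic carbon of a six-membered aromatic ring of carbon only, para to a large group. Going by the values given here, no measured step gives a readable size for this kind of change. With all three values at the limit (the limit of > 1000000 nM in this assay, at which 3 of the 3 values shown sit), compound 4 is expected to stay at or near that limit, and the step that the limit leaves unreadable from compound 1 to compound 4 is estimated to be nil within the scatter. Compound 4 is estimated at 1500000 nM, with a range of 300000 nM to 10000000 nM.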

Compound 4, half-maximal inhibitory concentration: > 1000000 nM
Compound 4 was reported as a limit (the forecaster's own chance of this, stated with the estimate: 85%); the middle value lies beyond the limit too.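

The steps from compound 1 and from compound 2 to compound 4 cannot be read, as both ends of each are limits: the limit of > 1000000 nM in this assay, at which 4 of the 4 values shown sit.

The compounds shown leave open whether fluoro, tert-butyl or the two chloro groups of compound 3 change cytotoxicity at all, and by how much.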